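One Methyl Removed From Two Related Cores

A few compounds are considered here, and "the series" means these few. Any claim that something is new, unique, unknown or untested is made for them only; others in the source may bear on it.

Compound 1 `COc1ccc(Br)cc1C(C)NC(=O)NS(=O)(=O)c1ccc(C)cc1` and compound 3 `COc1ccc(Br)cc1C(C)NC(=O)NS(=O)(=O)c1ccccc1` share a core and differ in one place: hydrogen in place of methyl on an aromatic carbon. In a functional assay on thoracic aorta (Rattus norvegicus, strain Wistar), with a stated time of 15 min (a lower number here means that less compound is needed, a higher number that more compound is needed for the effect), compound 1 gives > 300000 nM, which is a limit of the assay rather than a number. In this assay compound 3 gives > 300000 nM, again a limit. The step that the two limits leave unreadable from compound 1 to compound 3 therefore cannot be sized, as both values sit at the limit of > 300000 nM in this assay, at which 3 of the 3 values shown sit.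

Compound 2 `COc1ccc(OC)c(CNC(=O)NS(=O)(=O)c2ccc(C)cc2)c1` is built on a second core; the difference between the two cores is not broken down here. In this assay compound 2 gives > 300000 nM, also a limit. Compound 4 `COc1ccc(OC)c(CNC(=O)NS(=O)(=O)c2ccccc2)c1` has not yet been measured and differs from compound 2 by the same change, at the same place: hydrogen in place of methyl on an aromatic carbon.

Because the step that the two limits leave unreadable from compound 1 to compound 3 stayed unreadable between two limits, the step from compound 2 to compound 4 is expected to be a number no higher from compound 2 to compound 4 (the limit leaves the size open), with no readable size. For compound 4 in this assay the expected value is 300000 nM, most probably reported again only as a limit.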

Compound 4, half-maximal effective concentration: > 300000 nM
Compound 4: only a limit was reported; the forecaster's own chance of this, stated with the estimate: 90%; the middle value lies on the limit itself.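

Compound 2 and compound 4 both give a limit in this assay rather than a number, and the step between them cannot be read. All the results shown stop at the same point: the limit of > 300000 nM in this assay, at which 4 of the 4 values shown sit. The compounds shown leave open whether 4-methylphenyl to phenyl alters the concentration needed, and what structure would give a measurable value.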